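This account rests on a few compounds, and the source may have more. Where it says the series, first, only, none or still open, it means among the compounds named here.

Measured compounds:
compound 1 `COc1cccc(NC(=O)COc2ccc3cc(/C=C4/SC(=O)NC4=O)ccc3c2)c1`, 1600 nM
compound 2 `O=C(COc1ccc2cc(/C=C3/SC(=O)NC3=O)ccc2c1)Nc1ccc(F)cc1`, 1600 nM

In an assay on isolated protein for inhibition of histone deacetylase 4 (Homo sapiens), with a stated time of 1 h (on this read-out lower numbers stand for stronger inhibition and higher numbers for weaker inhibition), compound 1 gives 1600 nM and compound 2 gives 1600 nM. The step of no change at the digits printed from compound 1 to compound 2 (within the scatter) shows that swapping the aryl group on the amide nitrogen left the value within the scatter, so compound 2 stands level with compound 1.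

Compound 3 `O=C(COc1ccc2cc(/C=C3/SC(=O)NC3=O)ccc2c1)Nc1ccc(Br)cc1` differs from compound 2 by bromo in place of fluoro on an aromatic carbon. Among the measured compounds shown here, only the step from compound 1 to compound 2 bears on this, and it was flat, so no step beyond the scatter is expected in this assay. Compound 3 is therefore expected to give 1500 nM, between 700 nM and 3500 nM. The step of a 1.1-fold lower number from compound 2 to compound 3 (0.03 log units; within the scatter) is estimated to stay within the scatter.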

Compound 3, half-maximal inhibitory concentration: 2900 nM
Beside the measured number, compound 3's estimate is 1.9-fold (0.29 log units) below it; measured number inside the range.
By their numbers in this assay, from the lowest: compounds 1, 2 and 3 (each within the scatter of the next).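

Bromo in place of fluoro gives a 1.8-fold higher number from compound 2 to compound 3 (0.26 log units; within the scatter) in this assay and 4-bromophenyl in place of 3-methoxyphenyl gives a 1.8-fold higher number from compound 1 to compound 3 (0.26 log units; within the scatter) on the same read-out. Across these three aryl groups on the amide nitrogen, including two halogens at the same place, the values therefore all stay within the scatter of one another. Nothing on hand bears on why this position responds so little.

Still open, on these data alone, is whether an amine or a carboxylic acid on this phenyl ring would move the number beyond the scatter. The same holds for a longer chain between the amide and the shared core.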